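The compounds below may be only part of what the source reports. "The series", "measured", "known", "first", "only" and "open" are said of these compounds alone.

Three ureas on a shared core have been measured in a functional assay on GBM2 cells (Homo sapiens) for antiproliferative activity, read by WST assay, with a stated time of 72 h; on this read-out higher numbers stand for weaker inhibition and lower numbers for stronger inhibition. Compound 1 `O=C(Nc1cccc(F)c1)Nc1cc2ncncc2cc1OCc1cccc(Cl)c1` gives 7800 nM in this assay. Compound 2 `O=C(Nc1cccc(Cl)c1)Nc1cc2ncncc2cc1OCc1ccccc1` gives 4100 nM, and compound 3 `O=C(Nc1ccc(Cl)c(Cl)c1)Nc1cc2ncncc2cc1OCc1ccccc1F` gives 6000 nM. Compound 1 carries the highest of the three numbers, yet its gaps to compound 3 and to compound 2 both lie within the usual scatter, so the three stand together and no order among them can be read; none of them reaches strong inhibition.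

Compound 4 `O=C(Nc1ccccc1F)Nc1cc2ncncc2cc1OCc1cccc(Cl)c1` has not been measured. It differs from compound 1 in one place: 2-fluorophenyl in place of 3-fluorophenyl on an amide-type nitrogen. The two have the same atoms, joined differently. Among the measured compounds shown here, no measured pair in the set shows this change on its own, and the three measured compounds differ from one another in several places at once, so they give no guide to its size. With only compound 1 at 7800 nM as anchor, the step is expected to be small, in no fixed direction, and to stay within the scatter. For compound 4 the expected value in this assay is 8000 nM, with a range from 3500 nM to 18000 nM. The expected step of a 1.0-fold higher number from compound 1 to compound 4 (0.01 log units; within the scatter) is therefore read as no change beyond the scatter.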

Compound 4, half-maximal inhibitory concentration: 4400 nM
Compound 4: the middle estimate sits 1.8-fold (0.26 log units) above what was measured, and the stated range covers the measured number.
By their numbers in this assay, from the lowest: compounds 2, 4, 3 and 1 (each within the scatter of the next).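

Among the compounds shown here, the pair is the first single-place comparison: with the rest of compound 1 held fixed, 2-fluorophenyl in place of 3-fluorophenyl on an amide-type nitrogen gives a 1.8-fold lower number from compound 1 to compound 4 (0.25 log units; within the scatter) in this assay. For the compounds shown here, on this read-out, the two fluorophenyl isomers therefore cannot be told apart at this place, and compound 4, like the earlier compounds, does not reach strong inhibition. Nothing on hand bears on what lies behind this result.

Still open, as far as these compounds go, is whether a different kind of group on this amide-type nitrogen, such as an aminophenyl, a carboxylic acid-bearing phenyl or a longer alkyl chain, would give a step beyond the scatter. Also open, from the compounds shown here alone, is whether the same isomer change stays this small when the rest of the molecule differs.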